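The source may hold more compounds than are shown below. What is called first, only, known or untested is meant among the compounds shown, and "the series" means these compounds.

Of the compounds shown here, three on one shared core have so far been measured in an assay for inhibition of Dihydrofolate reductase (Gallus gallus); on this read-out higher numbers stand for weaker inhibition and lower numbers for stronger inhibition. Compound 1 `COc1ccccc1Cc1cnc(N)nc1N` gives 28800 nM in this assay. Compound 2 `CCOc1ccccc1Cc1cnc(N)nc1N` gives 24500 nM in this assay, and compound 3 `NC(=O)COc1ccccc1Cc1cnc(N)nc1N` gives 33900 nM in this assay. Compound 3 thus carries the highest of the three numbers, but it lies within the scatter of both others: the step of a 1.2-fold higher number from compound 1 to compound 3 (0.07 log units; within the scatter), the step of a 1.4-fold higher number from compound 2 to compound 3 (0.14 log units; within the scatter) and the step of a 1.2-fold lower number from compound 1 to compound 2 (0.07 log units; within the scatter) are all small.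

The unmeasured compound 4 `Nc1ncc(Cc2ccccc2I)c(N)n1` differs from compound 3 by iodo in place of carbamoylmethoxy on an aromatic carbon. Within the data shown here, none of the measured steps bears directly on this change. Each of them altered only what sits on the saturated chain carbon bound to the oxygen on the aromatic ring, whereas here the entire carbamoylmethoxy group, oxygen included, gives way to iodo. What those steps do show is that varying the group on that carbon left the number in this assay unchanged beyond the scatter.

For compound 4 no step beyond the scatter is therefore expected with any confidence, and the expected step is set as a 1.1-fold lower number from compound 3 to compound 4 (0.05 log units; within the scatter). Compound 4 is estimated at 30000 nM in this assay, with a wide range from 8000 nM to 110000 nM.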

Compound 4, inhibition constant: 8710 nM
Compound 4: middle estimate off by 3.4-fold (0.54 log units), on the high side, and the stated range covers the measured number.
By their numbers in this assay, from the lowest: compound 4; then compounds 2, 1 and 3 (each within the scatter of the next).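

Among these compounds, on the aromatic carbon itself, the change has an effect that the earlier steps on the saturated chain carbon did not show: replacing the whole carbamoylmethoxy group with iodo gives a 3.9-fold lower number from compound 3 to compound 4 (0.59 log units; beyond the scatter) in this assay. The same holds when iodo takes the place of the smaller oxygen-linked groups, with ethoxy giving a 2.8-fold lower number from compound 2 to compound 4 (0.45 log units; beyond the scatter) and methoxy giving a 3.3-fold lower number from compound 1 to compound 4 (0.52 log units; beyond the scatter), so compound 4 is the strongest inhibitor of the four, though each step is modest and the three oxygen-linked compounds remain within the scatter of one another. No measured finding is available to explain why iodo at this position gives the lower number.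

The four compounds cannot show whether the step follows from losing the oxygen attached to the aromatic ring or from gaining iodine, since both happen in the same change. From the compounds shown here alone, whether bromo, chloro, methyl or an amine on this aromatic carbon would give a number near that of compound 4, or near those of the oxygen-linked compounds, also remains open.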